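Swapping the Sulfonyl Aryl Group: Compound 2 to Compound 3

A few compounds are considered here, and "the series" means these few. Any claim that something is new, unique, unknown or untested is made for them only; others in the source may bear on it.

Compound 1 `O=C1C=CC(O)(c2cc3ccccc3n2S(=O)(=O)c2ccccc2)C=C1`: 30 nM
Compound 2 `Cc1ccc(S(=O)(=O)n2c(C3(O)C=CC(=O)C=C3)cc3ccccc32)cc1`: 30 nM

In a functional assay on HCT-116 cells (Homo sapiens) for inhibition, read by MTT assay, with a stated time of 72 h (on this read-out higher numbers stand for weaker inhibition and lower numbers for stronger inhibition), compound 1 stands level with compound 2, at 30 nM. Compound 3 `O=C1C=CC(O)(c2cc3ccccc3n2S(=O)(=O)c2cccnc2)C=C1` carries pyridin-3-yl in place of 4-methylphenyl on a sulfonyl sulfur. Going by the values given here, only one measured step bears on this change, and it also concerns the group on the sulfonyl sulfur. That step, no change at the digits printed from compound 1 to compound 2 (within the scatter), came with methyl in place of hydrogen on an aromatic carbon. Among the compounds with values here, no measured compound has a ring nitrogen in this group, so the evidence is thin and the range must stay wide. In this assay, no step beyond the scatter is expected, in either direction. The expected step is a 1.3-fold higher number from compound 2 to compound 3 (0.12 log units; within the scatter). For compound 3, the estimated value is 40 nM, with an expected range from 15 nM to 120 nM.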

Compound 3, half-maximal inhibitory concentration: 30 nM
Estimate against measurement, compound 3: 1.3-fold (0.12 log units) above; low and high end bracket the measured number.
By their numbers in this assay, from the lowest: compounds 1, 2 and 3 (each within the scatter of the next).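

Going by these compounds alone, until now, the only change at this position was a methyl on the aromatic ring attached to the sulfonyl sulfur, with the ring itself remaining all carbon. In this assay, putting a ring nitrogen into this group gives no change at the digits printed from compound 2 to compound 3 (within the scatter) with pyridin-3-yl in place of 4-methylphenyl, and no change at the digits printed from compound 1 to compound 3 (within the scatter) with pyridin-3-yl in place of phenyl, so a ring with a hetero atom and a hydrogen-bond acceptor reads the same here as both carbon rings. Nothing measured explains why the number stays in place.

Still open, on these data alone, is whether the same holds for pyridin-2-yl or pyridin-4-yl, where the ring nitrogen sits elsewhere. It is also unknown how this read-out responds to an amine or a carboxylic acid on the ring, or to a simple methyl or longer alkyl chain replacing the ring on the sulfonyl sulfur.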